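This account rests on a few compounds, and the source may have more. Where it says the series, first, only, none or still open, it means among the compounds named here.

Compound 1 `CCCCNc1nc(N)nc2c1CN(C)CC2` carries hydrogen on a saturated chain carbon bound to an amine nitrogen in a ring; in an assay on HEK293 cells for agonist activity at Toll-like receptor 8 (Homo sapiens), read by a luciferase reporter, with a stated time of 6 h (a higher number here means that more compound is needed for the effect, a lower number that less compound is needed), compound 1 gives 0.03 uM. Compound 2 `CCCCNc1nc(N)nc2c1CN(Cc1c(Cl)cccc1Cl)CC2` differs only in that place, and in this assay compound 2 gives 0.14 uM. Among the measured compounds shown here, the single measured step, a 4.7-fold higher number from compound 1 to compound 2 (0.67 log units; beyond the scatter), places compound 2 highest of the two numbers so far, with compound 1 as its nearest neighbour.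

Compound 3 `CCCCNc1nc(N)nc2c1CN(Cc1ccccn1)CC2` is the next member: pyridin-2-yl in place of 2,6-dichlorophenyl on a saturated chain carbon bound to an amine nitrogen in a ring. For the measured compounds named here, only the step from compound 1 to compound 2 bears on this change, as it touches the same place: introducing the 2,6-dichlorophenyl group there raised the number by a modest amount. Compound 3 keeps an aromatic ring in that place, but one with one hetero atom instead of the carbon-only ring, so the expectation is a number between those of compound 2 and compound 1, shifted toward compound 1 but perhaps no further than the scatter allows. For compound 3 the expected step is a 1.8-fold lower number from compound 2 to compound 3 (0.24 log units; within the scatter), a modest move to a lower number. Compound 3 is therefore estimated at 0.08 uM in this assay, with a range from 0.03 uM to 0.25 uM.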

Compound 3, minimum effective concentration: 0.07 uM
Compound 3: middle estimate off by 1.1-fold (0.06 log units), on the high side, within the range that was stated.
By their numbers in this assay, from the lowest: compound 1; then compounds 3 and 2 (each within the scatter of the next).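

In this assay the exchange of 2,6-dichlorophenyl for pyridin-2-yl on a saturated chain carbon bound to an amine nitrogen in a ring gives a 2.0-fold lower number from compound 2 to compound 3 (0.30 log units; within the scatter) and so does not separate the two aromatic groups at this place, even though the two chlorine atoms leave and a ring nitrogen with one hydrogen-bond acceptor enters. Among the compounds shown here, the second new step, a 2.3-fold higher number from compound 1 to compound 3 (0.37 log units; beyond the scatter), shows that the separation from compound 1 seen with 2,6-dichlorophenyl also holds for a second aromatic group, so within these three compounds the clear difference at this place lies between hydrogen and either aromatic ring, with no compound going against it. No measured information is available to explain either step.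

The compounds shown leave open how plain phenyl would read at this place, so the part played by the chlorine atoms cannot be separated from that of the ring nitrogen. They also leave open whether an aromatic ring is needed at all, which a cyclohexyl group, a longer alkyl chain or a carboxylic acid at the same carbon would address.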